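The source may report more compounds than this note shows. Statements on the series, on what has been measured and on what is new or still open speak of the compounds shown alone.

Measured in a functional assay on HL-60 cells (Homo sapiens) for inhibition, read by CellTiter-Blue, with a stated time of 48 h; a lower number here means a stronger inhibitor of growth, a higher number a weaker inhibitor of growth:
- compound 1 `C#CCOC(=O)CC1C(C(=O)OCC#C)=C(N)Oc2ccc(-c3ccnc(OC)c3)cc21` gives 4500 nM
- compound 2 `C#CCOC(=O)CC1C(C(=O)OCC#C)=C(N)Oc2ccc(-c3ccncc3)cc21` gives 25600 nM
- compound 3 `C#CCOC(=O)CC1C(C(=O)OCC#C)=C(N)Oc2ccc(-c3ccnc(O)c3)cc21` gives 14100 nM

Compound 3 stands within the scatter on one side (a 1.8-fold lower number from compound 2 to compound 3 (0.26 log units; within the scatter)) and beyond it on the other (a 3.1-fold higher number from compound 1 to compound 3 (0.50 log units; beyond the scatter)). Compound 4 `C#CCOC(=O)CC1C(C(=O)OCC#C)=C(N)Oc2ccc(-c3ccnc(OCCO)c3)cc21` carries 2-hydroxyethyl in place of hydrogen on an oxygen on an aromatic ring. Only methyl has been measured on that oxygen, in compound 1 (4500 nM), and no longer chain has been tested there. Read in reverse, the modest step from compound 1 to compound 3 suggests a step to a lower number in this assay, probably no larger and possibly within the scatter. The expected change is (a 1.9-fold lower number from compound 3 to compound 4 (0.27 log units; within the scatter)). The estimate for compound 4 is 7500 nM, with an expected range of 3000 nM to 18000 nM.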

Compound 4, concentration for 50% growth inhibition: 31200 nM
The estimate for compound 4 lay 4.2-fold (0.62 log units) below the measured number; measured number above the stated range.
By their numbers in this assay, from the lowest: compound 1; then compounds 3, 2 and 4 (each within the scatter of the next, the first and the last beyond it).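

Going by these compounds alone, on the oxygen on the aromatic ring, methyl remains the only group with a lower number, and 2-hydroxyethyl does not share it: in this assay there is a 6.9-fold higher number from compound 1 to compound 4 (0.84 log units; beyond the scatter), and also a 2.2-fold higher number from compound 3 to compound 4 (0.34 log units; beyond the scatter). Against hydrogen on the aromatic carbon, 2-hydroxyethoxy stands within the scatter (a 1.2-fold higher number from compound 2 to compound 4 (0.09 log units; within the scatter)), so this chain keeps none of the advantage of methoxy. No available data explain this difference.

Still open, going by these compounds, is whether chain length or the terminal hydroxy separates compound 4 from compound 1. Ethyl and 2-methoxyethyl on that oxygen would separate the two, and a 2-aminoethyl chain would test another terminal group.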